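(4-Fluorophenyl)sulfonyl on the ring amine of compound 2

The source may report more compounds than this note shows. Statements on the series, on what has been measured and on what is new or still open speak of the compounds shown alone.

In an ADME assay on L02 cells (Homo sapiens) for cytotoxicity, read by MTT assay, with a stated time of 24 h (on this read-out higher numbers stand for weaker inhibition and lower numbers for stronger inhibition), compound 2 `O=C1/C(=C/c2cccnc2)CNC/C1=C\c1ccccc1F` gives 15900 nM and compound 1 `CN1C/C(=C\c2cccnc2)C(=O)/C(=C/c2cc([N+](=O)[O-])ccc2F)C1` gives 15700 nM, so the two stand level within the scatter. Compound 3 `O=C1/C(=C/c2cccnc2)CN(S(=O)(=O)c2ccc(F)cc2)C/C1=C\c1ccccc1F` carries (4-fluorophenyl)sulfonyl in place of hydrogen on an amine nitrogen in a ring. Within the data shown here, no measured pair isolates this change, so the expectation is tentative: a modest step towards stronger inhibition in this assay, near the edge of the scatter. The expected change is a 2.0-fold lower number from compound 2 to compound 3 (0.30 log units; within the scatter). For compound 3 the estimated value is 8000 nM, with an expected range of 2500 nM to 25000 nM.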

Compound 3, half-maximal inhibitory concentration: 15600 nM
The estimate for compound 3 lay 2.0-fold (0.29 log units) below the measured number; measured number inside the range.
By their numbers in this assay, from the lowest: compounds 3, 1 and 2 (each within the scatter of the next).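

With (4-fluorophenyl)sulfonyl in place of hydrogen on the amine nitrogen in the ring, the series shows a 1.0-fold lower number from compound 2 to compound 3 (0.01 log units; within the scatter) in this assay and so stands level within the scatter. This position therefore carries the much larger group with no readable change in this cytotoxicity read-out, which compound 1 and compound 2 alone could not show. No measurement here offers an explanation for this result.

Still open, going by these compounds, is whether an acetyl group, a methanesulfonyl group or an unsubstituted benzenesulfonyl group on this nitrogen would also stay level. Also open, on these data alone, is whether a basic aminoethyl chain there would shift the number.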